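Cross-conjugated dienones: aryl substituent change, fluoro to cyano

A few compounds are considered here, and "the series" means these few. Any claim that something is new, unique, unknown or untested is made for them only; others in the source may bear on it.

Two compounds of the shared core carry a single substituent on the aryl ring. In a functional assay on IMR-32 cells (Homo sapiens) for cytotoxicity, read by sulforhodamine B assay, with a stated time of 48 h (on this read-out higher numbers stand for weaker inhibition and lower numbers for stronger inhibition), compound 1 `CC1=C(/C=C/C(=O)/C=C/c2ccc(Br)cc2)C(C)(C)CCC1` gives 10400 nM, and compound 2 `CC1=C(/C=C/C(=O)/C=C/c2ccc(F)cc2)C(C)(C)CCC1` gives 7400 nM. Going by the values given here, the one step between them, a 1.4-fold lower number from compound 1 to compound 2 (0.15 log units; within the scatter), does not rise above the scatter. Compound 2 therefore stands at the low end of the two numbers shown, with compound 1 as its nearest neighbour and no separation beyond the scatter between the pair.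

Compound 3 `CC1=C(/C=C/C(=O)/C=C/c2ccc(C#N)cc2)C(C)(C)CCC1` is the next member: cyano in place of fluoro on an aromatic carbon. Among the compounds with values here, only the step from compound 1 to compound 2 bears on this change, as it is the sole substitution seen at the same aromatic carbon, and that step was small. Within the data shown here, no measured step covers a cyano group, so the expectation rests on that single small swap alone. For compound 3 a step in this assay that stays within the scatter is expected, amounting to a 1.0-fold higher number from compound 2 to compound 3 (0.01 log units; within the scatter) with no firm direction. Compound 3 is thus estimated at 7500 nM, with a range from 3000 nM to 20000 nM.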

Compound 3, half-maximal inhibitory concentration: 23400 nM
Beside the measured number, compound 3's estimate is 3.1-fold (0.49 log units) below it; the whole stated range lies below it.
By their numbers in this assay, from the lowest: compounds 2 and 1 (each within the scatter of the next); then compound 3.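

At this position, an aromatic carbon para to a large group, the substituent does register in this assay: cyano in place of fluoro gives a 3.2-fold higher number from compound 2 to compound 3 (0.50 log units; beyond the scatter), and cyano in place of bromo gives a 2.3-fold higher number from compound 1 to compound 3 (0.35 log units; beyond the scatter). Both steps are modest, yet both run in the same direction, so the position is not indifferent to what it carries, as the bromo and fluoro pair alone had suggested; compound 3 is the weakest of the three, while compounds 1 and 2 remain within the scatter of each other. No accompanying data on these compounds offer any account of why the nitrile departs from the two halogens.

Going by these compounds alone, with only three members, it remains open whether the shift is peculiar to the cyano group or would also appear with an amine, a carboxylic acid or a methoxy group on the same carbon. Also open, on these data alone, is whether the cyano group would produce a step of similar size from another carbon of the aromatic ring, or on the core with a different substitution pattern.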